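One Methoxy Group Less: Expected Loss of Effect

The source may report more compounds than this note shows. Statements on the series, on what has been measured and on what is new or still open speak of the compounds shown alone.

Compound 1 `COc1cc(-c2cc(/C=C/C(=O)c3ccc(N)cc3)[nH]n2)cc(OC)c1OC` and compound 2 `COc1ccc(-c2cc(/C=C/C(=O)c3ccc(N)cc3)[nH]n2)cc1OC` share one core and differ in a single place, (hydrogen in place of methoxy on an aromatic carbon). In a functional assay on NCI-H226 cells (Homo sapiens) for cytotoxicity, read by sulforhodamine B assay, with a stated time of 48 h, tested at 10 uM (on this read-out lower numbers stand for a stronger effect and higher numbers for a weaker effect at the one concentration tested), compound 1 gives -73%. Measured the same way, compound 2 gives -13%. The step of a number 60 percentage points higher from compound 1 to compound 2 (beyond the scatter).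

Compound 3 `COc1cc(C(=O)/C=C/c2cc(-c3cc(OC)c(OC)c(OC)c3)n[nH]2)cc(OC)c1OC` rests on a different core; the difference between the two cores is not broken down here. In this assay compound 3 gives -92%, the lowest of the three numbers, with compound 1 nearest and compound 2 furthest.

Compound 4 `COc1ccc(-c2cc(/C=C/C(=O)c3cc(OC)c(OC)c(OC)c3)[nH]n2)cc1OC` is not yet measured. It differs from compound 3 by hydrogen in place of methoxy on an aromatic carbon, which is the same change that sets compound 2 apart from compound 1, at a place described in the same words. Since the step of a number 60 percentage points higher from compound 1 to compound 2 (beyond the scatter) was large and beyond the scatter, compound 4 is expected to lose much of the effect of compound 3. In this assay compound 4 is therefore expected to give about -40%, within a range from -70% to -10%. That estimate means an expected step of a number 52 percentage points higher from compound 3 to compound 4 (beyond the scatter), close in size to the earlier one.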

Compound 4, a percentage reported as activity, at one concentration (the size of the read-out at that concentration, not a potency): -8%
The estimate for compound 4 lay 32 percentage points below the measured number, outside the stated range (above it).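

Hydrogen in place of methoxy on an aromatic carbon gave, in this assay, a number 84 percentage points higher from compound 3 to compound 4 (beyond the scatter), so on both cores the change went the same way and the effect was largely lost. The size of the step, however, did not carry over unchanged from one core to the other: the same change on two cores in this assay, a number 60 percentage points higher (beyond the scatter) from compound 1 to compound 2 and a number 84 percentage points higher (beyond the scatter) from compound 3 to compound 4, 24 percentage points apart, beyond the scatter of two such steps These two pairs therefore support the direction of the change on these two cores only; they do not give a size that can be transferred, do not explain why the two steps differ, and, with one concentration tested, say nothing about potency.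

The compounds shown leave open whether another group in the same place, such as a hydroxyl, an ethoxy group or a fluorine atom, would keep more of the effect than hydrogen does. They also leave open how replacing any of the other methoxy groups of compound 3 would change the number in this assay.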